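Cytotoxicity notes on the diarylpyrimidine series: fluoro to chloro

The source may hold more compounds than are shown below. What is called first, only, known or untested is meant among the compounds shown, and "the series" means these compounds.

Measured so far:
- compound 1 `N#Cc1ccc(Nc2nccc(N(CCCO)c3c(F)cc(-c4ccc(C#N)cc4)cc3F)n2)cc1`: 68000 nM
- compound 2 `N#Cc1ccc(Nc2nccc(N(CCCF)c3c(F)cc(-c4ccc(C#N)cc4)cc3F)n2)cc1`: 241000 nM

In an ADME assay on MT4 cells (Homo sapiens) for cytotoxicity, read by MTT assay, with a stated time of 5 days (on this read-out lower numbers stand for higher toxicity in this test and higher numbers for lower toxicity in this test), compound 2 gives 241000 nM, the higher of the two numbers recorded. Among the measured compounds shown here, its only neighbour is compound 1, which in this assay gives 68000 nM; the step of a 3.5-fold higher number from compound 1 to compound 2 (0.55 log units; beyond the scatter) is the single measured comparison in the set.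

Compound 3 `N#Cc1ccc(Nc2nccc(N(CCCCl)c3c(F)cc(-c4ccc(C#N)cc4)cc3F)n2)cc1` is not yet measured. It differs from compound 2 by chloro in place of fluoro on a saturated chain carbon, three bonds along the chain from a nitrogen on an aromatic ring. For the measured compounds named here, no measured step covers a halogen-for-halogen exchange at this position; the one available step, a 3.5-fold higher number from compound 1 to compound 2 (0.55 log units; beyond the scatter), concerns hydroxy to fluoro and so bears on the present change only loosely, showing that the group at the chain end can move the number by a modest amount. With nothing closer to lean on, the expectation for compound 3 is a step of a 1.2-fold lower number from compound 2 to compound 3 (0.08 log units; within the scatter), that is, no change beyond the scatter, with the range kept wide.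

Compound 3 is therefore estimated at 200000 nM in this assay, with a plausible span from 80000 nM to 500000 nM.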

Compound 3, half-maximal cytotoxic concentration: > 250000 nM
Compound 3 gave a limit, no number; the forecaster's own chance of this, stated with the estimate: 20%; at least 1.2-fold (0.09 log units) between middle value and limit.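

In this assay, going by these compounds, the halogen exchange on a saturated chain carbon, three bonds along the chain from a nitrogen on an aromatic ring, gives an at least 1.0-fold higher number from compound 2 to compound 3 (0.01 log units; that floor lies within the scatter), so 3-chloropropyl shows no sign of a lower number than 3-fluoropropyl, although the real size of the step stays unknown. Replacing hydroxy with a halogen now has a second example pointing the same way, an at least 3.6-fold higher number from compound 1 to compound 3 (0.56 log units; beyond the scatter), which leaves compound 1 with the lowest reading of the three and both halogen compounds clear of it by more than the scatter. The reading for compound 3 is a limit of the assay and not a number, so the halogen comparison has a floor and no upper end: the limit of > 250000 nM in this assay, at which 1 of the 3 values shown sits.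

Any order between compound 2 and compound 3 remains open, since the reading for compound 3 cannot be placed against the value for compound 2. Also open, on these data alone, is whether an amine, a carboxylic acid or a longer chain at this position would fall nearer compound 1 or nearer the two halogen compounds.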